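Swapping nitro for chloro on the biaryl tail

The source may hold more compounds than are shown below. What is called first, only, known or untested is meant among the compounds shown, and "the series" means these compounds.

Compound 1 `CN(CC1=CC[C@H]2C[C@@H]1C2(C)C)Cc1ccc(-c2cccc(C(F)(F)F)c2)cc1` gives > 316 nM in an assay on HEK293 cells for displacement of a labelled ligand from C-X-C chemokine receptor type 3 (Homo sapiens) (on this read-out higher numbers stand for weaker inhibition and lower numbers for stronger inhibition), a limit of the assay rather than a number.
Compound 2 `COC(=O)c1cccc(-c2ccc(CN(C)CC3=CC[C@H]4C[C@@H]3C4(C)C)cc2)c1` gives > 316 nM in this assay, again a limit.
Compound 3 `CN(CC1=CC[C@H]2C[C@@H]1C2(C)C)Cc1ccc(-c2cccc([N+](=O)[O-])c2)cc1` gives 2000 nM in this assay.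

All three share the same core and differ only in the group on the outer aromatic ring. Compound 3 is the only one of the three to return an actual number; the other two sit at the limit described by the limit of > 316 nM in this assay, at which 2 of the 3 values shown sit. The step that the limit leaves unreadable from compound 1 to compound 3 and the step that the limit leaves unreadable from compound 2 to compound 3 cannot be sized, and the step that the two limits leave unreadable from compound 1 to compound 2 is likewise unreadable.

Compound 4 `CN(CC1=CC[C@H]2C[C@@H]1C2(C)C)Cc1ccc(-c2cccc(Cl)c2)cc1` is not yet measured. It differs from compound 3 by chloro in place of nitro on an aromatic carbon. Among the compounds with values here, no measured step bears on this change: none of the three compounds carries chloro, and the two steps that end at compound 3 have no readable size. The expectation therefore rests on compound 3 alone, with no direction that the numbers support. Compound 4 is estimated at 2000 nM, with a wide range from 500 nM to 8000 nM that reaches the limit on the weak side, and the expected step is no change at the digits printed from compound 3 to compound 4 (within the scatter).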

Compound 4, inhibition constant: 3980 nM
The estimate for compound 4 lay 2.0-fold (0.30 log units) below the measured number; the measured number falls inside the stated range.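

In this assay, within the data shown here, the change from 3-nitrophenyl to 3-chlorophenyl gives the first step at this position whose size can be read: a 2.0-fold higher number from compound 3 to compound 4 (0.30 log units; within the scatter). The exchange is a real change in the atoms, with 3 heavy atoms and 2 hydrogen-bond acceptors leaving and 1 heavy atom and 0 hydrogen-bond acceptors entering, yet on this read-out compound 3 and compound 4 cannot be told apart. The steps that join compound 1 and compound 2 to compound 4 cannot be read, because compound 1 and compound 2 each give a limit and not a number: the limit of > 316 nM in this assay, at which 2 of the 4 values shown sit.

Among these compounds, whether an amine, a hydroxyl or a carboxylic acid on this same aromatic carbon would give a step beyond the scatter remains open, since the nitro-to-chloro pair is the only readable comparison here. The actual numbers of compound 1 and compound 2 are also unknown, so how trifluoromethyl and methoxycarbonyl compare with nitro and chloro at this position remains unsettled.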